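A few compounds are considered here, and "the series" means these few. Any claim that something is new, unique, unknown or untested is made for them only; others in the source may bear on it.

Working notes on the series. Compound 1 `CN(CCCN1CCCCC1)c1cccc(C(=O)N2CCc3ccc(OS(N)(=O)=O)cc3C2)c1` carries the shared sulfamate core; in an assay on HEK293 cells for inhibition of Steryl-sulfatase (Homo sapiens), tested at 1 uM (on this read-out lower numbers stand for a weaker effect and higher numbers for a stronger effect at the one concentration tested), compound 1 gives 30.6%. Compound 2 `CN(C)CCN(Cc1ccccc1)c1ccc(C(=O)N2CCc3ccc(OS(N)(=O)=O)cc3C2)cc1` is built on the same core with a different amine arm, and in this assay compound 2 gives 57.8%. Compound 1 therefore stands lowest of the two numbers, with compound 2 higher by a gap beyond the scatter; the two compounds differ in more than one place, so those values say nothing direct about any single change.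

Compound 3 `CN(CCN1CCCCC1)c1cccc(C(=O)N2CCc3ccc(OS(N)(=O)=O)cc3C2)c1` has not yet been measured. It differs from compound 1 by piperidin-1-yl in place of (piperidin-1-yl)methyl on a saturated chain carbon, two bonds along the chain from a nitrogen on an aromatic ring. Among the compounds with values here, no measured pair isolates this chain shortening, so nothing beyond the two values above anchors it. The step of a number 2.6 percentage points lower from compound 1 to compound 3 (within the scatter) is expected to be small, within the scatter, with no clear direction. Compound 3 is estimated at 28%, with a range from 12% to 48%.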

Compound 3, a percentage reported as inhibition, at one concentration (the size of the read-out at that concentration, not a potency): 30.8%
The estimate for compound 3 lay 2.8 percentage points below the measured number; the measured number falls inside the stated range.
By their numbers in this assay, from the lowest: compounds 1 and 3 (each within the scatter of the next); then compound 2.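

Piperidin-1-yl in place of (piperidin-1-yl)methyl on a saturated chain carbon, two bonds along the chain from a nitrogen on an aromatic ring, gives a number 0.2 percentage points higher from compound 1 to compound 3 (within the scatter) in this assay, the first reading of a single change in this series. At this position, the read-out therefore does not separate the 3-(piperidin-1-yl)propyl chain from the 2-(piperidin-1-yl)ethyl chain. No measured evidence bears on this result.

From the compounds shown here alone, whether a longer chain such as 4-(piperidin-1-yl)butyl, or a morpholine or a dimethylamino group in place of the piperidine, would hold the number at this level remains open. Within the data shown here, also open is which of its several differences from the other two sets apart compound 2, at 57.8%, since no single-change step connects it to them.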